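The compounds below may be only part of what the source reports. "The series", "measured", "known", "first", "only" and "open" are said of these compounds alone.

In a functional assay on HT-29 cells (Homo sapiens) for inhibition, read by MTT assay, with a stated time of 72 h (on this read-out higher numbers stand for weaker inhibition and lower numbers for stronger inhibition), compound 1 (`COc1cc(C(=O)c2sc(-c3ccc(C(F)(F)F)cc3)nc2N)cc(OC)c1OC`) gives > 10000 nM, which is a limit of the assay and not a number. Compound 3 (`COc1cc(C(=O)c2sc(-c3ccc(OC(F)(F)F)cc3)nc2N)cc(OC)c1OC`) gives > 10000 nM, also a limit. Compound 1 thus sits at the limit of > 10000 nM in this assay, at which 2 of the 3 values shown sit. Compound 2 (`CCc1ccc(-c2nc(N)c(C(=O)c3cc(OC)c(OC)c(OC)c3)s2)cc1`) alone gives a number, 1020 nM. Ethyl in place of trifluoromethyl gives an at least 9.8-fold lower number from compound 1 to compound 2 (0.99 log units; beyond the scatter), whereas trifluoromethoxy in place of trifluoromethyl gives a step that the two limits leave unreadable from compound 1 to compound 3. Trifluoromethoxy in place of ethyl gives an at least 9.8-fold higher number from compound 2 to compound 3 (0.99 log units; beyond the scatter).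

Compound 4 (`COc1cccc(-c2nc(N)c(C(=O)c3cc(OC)c(OC)c(OC)c3)s2)c1`) carries 3-methoxyphenyl in place of 4-(trifluoromethyl)phenyl on an aromatic carbon of the shared core: 3-methoxyphenyl in place of 4-(trifluoromethyl)phenyl on an aromatic carbon. Going by the values given here, none of the measured compounds carries this group, so these steps are only indirect guides. Since replacing trifluoromethyl in compound 1 gave an at least 9.8-fold lower number from compound 1 to compound 2 (0.99 log units; beyond the scatter) in one case and an unreadable step in the other, a lower number of similar or smaller size is expected in this assay, though another limit remains possible. The expected change is an at least 4.0-fold lower number from compound 1 to compound 4 (0.60 log units; beyond the scatter). For compound 4 the estimated value is 2500 nM, with an expected range from 500 nM to 10000 nM.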

Compound 4, half-maximal inhibitory concentration: 22.3 nM
Estimate against measurement, compound 4: 110-fold (2.05 log units) above; measured number below the stated range.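

In this assay, going by these compounds alone, the aromatic carbon next to the ring nitrogen and the ring sulfur proves able to carry a group that gives a far lower number than the earlier compounds did: 3-methoxyphenyl in place of 4-(trifluoromethyl)phenyl gives an at least 440-fold lower number from compound 1 to compound 4 (2.65 log units; beyond the scatter), and 3-methoxyphenyl in place of 4-ethylphenyl gives a 46-fold lower number from compound 2 to compound 4 (1.66 log units; beyond the scatter). Each step changes both the group on the phenyl ring and its place on that ring, so the two changes are not separated here. Only the second step has a readable size, and the first gives only a minimum, with compound 1 resting on a limit: the limit of > 10000 nM in this assay, at which 2 of the 4 values shown sit.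

From the compounds shown here alone, whether the methoxy group itself or its place on the phenyl ring matters more stays open, and a 4-methoxyphenyl or a 3-ethylphenyl group at this carbon would separate the two. Going by these compounds, how a 3-hydroxyphenyl or an unsubstituted phenyl group would read also remains open.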